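The source may report more compounds than this note shows. Statements on the series, on what has been measured and on what is new or still open speak of the compounds shown alone.

Working notes on the series, all read in a functional assay with Homo sapiens as the target; on this read-out higher numbers stand for weaker inhibition and lower numbers for stronger inhibition. Compound 1 `O=C(NCc1ccc(F)cc1)c1ccc(Cl)[n+]([O-])c1` gives > 20000 nM, which is a limit of the assay and not a number. Compound 2 `O=C(NC1CCCCC1)c1ccc(Cl)[n+]([O-])c1` gives > 20000 nM, again a limit. Going by the values given here, compound 3 `CC(C)S(=O)(=O)c1ccc(C(=O)Nc2ccc(F)cc2)c[n+]1[O-]` gives 2000 nM, the only actual number available so far. The rest of the data amounts to the limit of > 20000 nM in this assay, at which 2 of the 3 values shown sit. Among the compounds with values here, no measured pair differs in one place only, so the series offers no measured step to calibrate against.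

The next compound, compound 4 `O=C(Nc1ccc(F)cc1)c1ccc(S(=O)(=O)C2CCCC2)[n+]([O-])c1`, keeps the rest of compound 3 and changes one group: cyclopentyl in place of isopropyl on a sulfonyl sulfur. In words, this is cyclopentyl in place of isopropyl on a sulfonyl sulfur. A small step in this assay is expected, leaning slightly towards stronger inhibition and quite possibly not beyond the usual scatter. Within the data shown here, the only anchor is compound 3 at 2000 nM. The estimated step is a 1.3-fold lower number from compound 3 to compound 4 (0.12 log units; within the scatter). For compound 4 the expected value is 1500 nM, with an estimated range of 500 nM to 6000 nM.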

Compound 4, half-maximal inhibitory concentration: 1900 nM
For compound 4 the middle estimate is 1.3-fold (0.10 log units) below the measured one, and the stated range covers the measured number.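

Cyclopentyl in place of isopropyl on a sulfonyl sulfur gives a 1.1-fold lower number from compound 3 to compound 4 (0.02 log units; within the scatter) in this assay, the only measured step in the series shown. At this position, a five-membered non-aromatic ring of carbon only and the open isopropyl group therefore read alike, even with the larger carbon count of the ring. No measured property among the data shown bears on this result.

From the compounds shown here alone, whether the same holds for groups that are not plain carbon stays open: an amine, a carboxylic acid or a longer chain on the sulfonyl sulfur would test it. Compounds 1 and 2 differ from compound 3 and compound 4 in more than one place, so they give no reading on the sulfonyl group itself.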